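From 3-nitrophenyl to 3,5-dimethylphenyl in compound 4

The source may report more compounds than this note shows. Statements on the series, on what has been measured and on what is new or still open speak of the compounds shown alone.

Three related compounds have been tested in a functional assay on HL-60 cells (Homo sapiens) for inhibition, read by CCK-8 assay, with a stated time of 48 h; a higher number here means a weaker inhibitor, a lower number a stronger inhibitor. Compound 1 (`COc1ccc(NC(=O)NCCNS(=O)(=O)c2ccc(-c3ccccc3OCc3ccccc3)s2)cc1`) gives > 50000 nM, which is a limit of the assay and not a number. Compound 2 (`O=[N+]([O-])c1ccc(NC(=S)NCCNS(=O)(=O)c2ccc(-c3ccccc3OCc3ccccc3)s2)cc1`) gives > 50000 nM, which is also a limit. Within the data shown here, compound 3 (`O=C(NCCNS(=O)(=O)c1ccc(-c2ccccc2OCc2ccccc2)s1)Nc1cccc([N+](=O)[O-])c1`) gives 2800 nM, the only actual number of the three and the strongest inhibition seen so far.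

Compound 4 (`Cc1cc(C)cc(NC(=O)NCCNS(=O)(=O)c2ccc(-c3ccccc3OCc3ccccc3)s2)c1`) keeps the shared core but changes one group: 3,5-dimethylphenyl in place of 3-nitrophenyl on an amide-type nitrogen. Put simply, 3,5-dimethylphenyl stands in place of 3-nitrophenyl on an amide-type nitrogen.

Among the measured compounds shown here, two measured steps bear on this change. The closer one is an at least 17-fold lower number from compound 1 to compound 3 (1.25 log units; beyond the scatter), in which 3-nitrophenyl replaces 4-methoxyphenyl on that same kind of nitrogen. The other is an at least 17-fold lower number from compound 2 to compound 3 (1.25 log units; beyond the scatter), which also involves this end of the molecule. Both are large, and both lead towards the compound that is about to lose its 3-nitrophenyl group. Neither tests a 3,5-dimethylphenyl group, so the size of the loss remains uncertain.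

The expected change is a 4.3-fold higher number from compound 3 to compound 4 (0.63 log units; beyond the scatter), which would mean a weaker inhibitor. For compound 4 the estimate in this assay is 12000 nM, with an expected range from 3500 nM to 40000 nM.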

Compound 4, half-maximal inhibitory concentration: 2200 nM
The estimate for compound 4 lay 5.5-fold (0.74 log units) above the measured number; the measured number lies below the stated range.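

In this assay the change gives a 1.3-fold lower number from compound 3 to compound 4 (0.10 log units; within the scatter), so 3-nitrophenyl, with its two hydrogen-bond acceptors, is not needed at this amide-type nitrogen: the all-carbon 3,5-dimethylphenyl serves equally well in this assay. The position is still not indifferent to what it carries, since replacing 4-methoxyphenyl gives an at least 22-fold lower number from compound 1 to compound 4 (1.35 log units; beyond the scatter), and replacing the sulfur-bearing group of compound 2 gives an at least 22-fold lower number from compound 2 to compound 4 (1.35 log units; beyond the scatter). These two steps give only a minimum size, because compound 1 and compound 2 each sit at a limit of the assay and not at a number: the limit of > 50000 nM in this assay, at which 2 of the 4 values shown sit.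

The compounds shown leave open whether a plain phenyl, a 3-methylphenyl or a 3-methoxyphenyl on this nitrogen would match compound 3 and compound 4, and so whether compound 1 suffers from its methoxy group or from where that group sits on the ring. They also leave open whether the sulfur or the 4-nitrophenyl group accounts for compound 2, a question that a 4-nitrophenyl group on the carbonyl version of this chain would help to settle.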